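Azetidinylmethoxypyridines: a Nitro Group in Place of Bromine

The compounds below may be only part of what the source reports. "The series", "measured", "known", "first", "only" and "open" are said of these compounds alone.

Measured compounds: compound 1 `Cc1ccc(OC[C@@H]2CCN2)cn1` with 0.057 nM; compound 2 `Brc1cncc(OC[C@@H]2CCN2)c1` with 0.18 nM.

Of the compounds shown here, two have been measured in an assay on brain for binding affinity to Neuronal acetylcholine receptor; alpha4/beta2 (Rattus norvegicus), read by radioligand binding; a higher number here means a weaker inhibitor, a lower number a stronger inhibitor. Compound 1 gives 0.057 nM, and compound 2 gives 0.18 nM, the higher of the two numbers; the gap between them lies beyond the scatter, so compound 2 is the weaker of the pair on this assay.

Compound 3 `O=[N+]([O-])c1cncc(OC[C@@H]2CCN2)c1` has not yet been measured. It differs from compound 2 in one place: nitro in place of bromo on an aromatic carbon. Among the compounds with values here, no measured pair shows the effect of this change, so there is no directly comparable step. Given that compound 2 sits at 0.18 nM, the author expects compound 3 to stay in the same sub-nanomolar region, with a step of a 1.7-fold higher number from compound 2 to compound 3 (0.22 log units; within the scatter) that is small and most likely within the scatter, leaning if anything toward a slightly weaker binder. The estimate for compound 3 in this assay is 0.3 nM, with a range from 0.08 nM to 1.2 nM.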

Compound 3, inhibition constant: 0.33 nM
Compound 3: the middle estimate sits 1.1-fold (0.04 log units) below what was measured, and the stated range covers the measured number.
By their numbers in this assay, from the lowest: compound 1; then compounds 2 and 3 (each within the scatter of the next).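

In this assay the exchange of bromo for nitro on an aromatic carbon, two atoms from the ring nitrogen, gives a 1.8-fold higher number from compound 2 to compound 3 (0.26 log units; within the scatter) and so stays within the scatter. Within the data shown here, this position therefore takes a nitro group of 3 heavy atoms, with 2 hydrogen-bond acceptors, in place of a single bromine without any change that this measurement can distinguish, which the earlier compounds could not show because no measured pair isolated a change at this position. Nothing in the data shown explains why the two groups read alike.

On these data alone, whether a smaller or differently built group at this position, such as an amine, a nitrile or a carboxylic acid, would also read alike remains open. So does whether nitro and bromo would stay level on any other receptor.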